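Amide side-chain variation on the shared core

This account rests on a few compounds, and the source may have more. Where it says the series, first, only, none or still open, it means among the compounds named here.

Three compounds built on the core of compound 1 `Cc1c(C(=O)NCCCN(C)C)oc2ccc(N(Cc3ccc(Br)cc3)S(=O)(=O)c3ccc(Br)cc3)cc12` have been measured in a functional assay on MCF7 cells (Homo sapiens) for antiproliferative activity, read by MTT assay, with a stated time of 48 h; on this read-out higher numbers stand for weaker inhibition and lower numbers for stronger inhibition. Compound 1 gives 3710 nM, the lowest of the three numbers. Compound 2 `Cc1c(C(=O)NCC(O)CO)oc2ccc(N(Cc3ccc(Br)cc3)S(=O)(=O)c3ccc(Br)cc3)cc12` gives 36500 nM, and compound 3 `Cc1c(C(=O)N2CCCC(C)C2)oc2ccc(N(Cc3ccc(Br)cc3)S(=O)(=O)c3ccc(Br)cc3)cc12` gives 32800 nM. The two steps away from compound 1 both lie beyond the scatter: a 9.8-fold higher number from compound 1 to compound 2 (0.99 log units; beyond the scatter) and an 8.8-fold higher number from compound 1 to compound 3 (0.95 log units; beyond the scatter). Between the other pair, a 1.1-fold lower number from compound 2 to compound 3 (0.05 log units; within the scatter).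

Compound 4 `Cc1c(C(=O)NCCNc2ccccc2)oc2ccc(N(Cc3ccc(Br)cc3)S(=O)(=O)c3ccc(Br)cc3)cc12` is not yet measured. It differs from compound 1 by anilino in place of (dimethylamino)methyl on a saturated chain carbon, two bonds along the chain from an amide-type nitrogen. Both measured steps from compound 1 also take away the dimethylamino-bearing chain end, and both give higher numbers of modest but clear size. For the measured compounds named here, compound 4 loses the same group while bringing in an anilino, and no measured compound carries an aromatic ring on this chain, so the expectation rests on compounds 2 and 3 alone. Compound 4 is expected to show a step of a 4.0-fold higher number from compound 1 to compound 4 (0.61 log units; beyond the scatter). Compound 4 is therefore estimated at 15000 nM, within a range of 5000 nM to 45000 nM.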

Compound 4, half-maximal inhibitory concentration: > 40000 nM
Compound 4: no number, only a limit (the forecaster's own chance of this, stated with the estimate: 10%); middle value at least 2.6-fold (0.42 log units) away from the limit.
By their numbers in this assay, from the lowest: compound 1; then compounds 3 and 2 (each within the scatter of the next). At a limit, above all of these: compound 4.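

In this assay compound 4 is read only as a limit: the limit of > 40000 nM in this assay, at which 1 of the 4 values shown sits.

Anilino in place of (dimethylamino)methyl gives an at least 10-fold higher number from compound 1 to compound 4 (1.03 log units; beyond the scatter), so a nitrogen retained on the chain, here the anilino one, does not by itself preserve the number of compound 1. The other two steps, an at least 1.2-fold higher number from compound 3 to compound 4 (0.08 log units; that floor lies within the scatter) and an at least 1.0-fold higher number from compound 2 to compound 4 (0.03 log units; that floor lies within the scatter), have floors within the scatter and set no order among these three compounds.

From the compounds shown here alone, compound 1 alone carries a dimethylamino end, so it stays open whether that group or some other feature of its chain goes with its lower number. A primary amine, a pyrrolidine or a morpholine at the end of the same 3-carbon propyl chain would separate these readings.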